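A few compounds are considered here, and "the series" means these few. Any claim that something is new, unique, unknown or untested is made for them only; others in the source may bear on it.

Measured compounds:
compound 1, `CN1CCN(c2ccc(Nc3ncc4nc(Nc5ccc(F)cc5)n([C@@H]5CCCNC5)c4n3)cc2)CC1`: in a functional assay on NCI-H1975 cells (Homo sapiens) for antiproliferative activity, read by MTT assay, with a stated time of 72 h (on this read-out higher numbers stand for weaker inhibition and lower numbers for stronger inhibition), compound 1 gives "not determined" (no result reported).
compound 2, `CN1CCN(c2ccc(Nc3ncc4nc(Nc5ccc(F)cc5)n([C@@H]5CCN(S(=O)(=O)C6CC6)C5)c4n3)cc2)CC1`: in this assay compound 2 gives > 10000 nM, which is a limit of the assay and not a number.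

Compound 2 therefore stands at the edge of what this assay can report, as shown by the limit of > 10000 nM in this assay, at which 1 of the 2 values shown sits, and compound 1 adds no number to set beside it. Going by the values given here, no step between measured compounds is available, so the step that matters here rests on the structural change alone. Compound 3, `CN1CCN(c2ccc(Nc3ncc4nc(Nc5ccc(F)cc5)n(-c5cccc(NC(=O)CO)c5)c4n3)cc2)CC1`, differs from compound 2 as follows: 3-(((hydroxymethyl)carbonyl)amino)phenyl in place of 1-(cyclopropylsulfonyl)pyrrolidin-3-yl on an aromatic nitrogen. Given the limit for compound 2, a step beyond the usual scatter toward stronger inhibition is expected, an at least 2.5-fold lower number from compound 2 to compound 3 (0.39 log units; beyond the scatter), though the amount is uncertain. The estimate for compound 3 in this assay is 4000 nM, with a range from 500 nM to 20000 nM, expected rather than known, and a limit remains possible.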

Compound 3, half-maximal inhibitory concentration: 580 nM
Beside the measured number, compound 3's estimate is 6.9-fold (0.84 log units) above it; the measured number falls inside the stated range.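

The substituent on the aromatic nitrogen of the five-membered aromatic ring can decide the read-out in this assay: with the rest of the structure unchanged, 3-(((hydroxymethyl)carbonyl)amino)phenyl in place of 1-(cyclopropylsulfonyl)pyrrolidin-3-yl gives an at least 17-fold lower number from compound 2 to compound 3 (1.23 log units; beyond the scatter). Compound 2 gives > 10000 nM, which is a limit of the assay and not a number. Compound 3 is the first compound here with a number, and the full size of the step remains unknown, since the step can be read only as a bound: the limit of > 10000 nM in this assay, at which 1 of the 3 values shown sits.

The change replaces the ring and its side group together, and the compounds shown do not tell which of the two carries the step. A plain phenyl group, or a methyl in place of the hydroxymethyl, would separate the contributions of the aromatic ring and the side group.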